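Fluoro removal on the shared core: notes on four analogues

A few compounds are considered here, and "the series" means these few. Any claim that something is new, unique, unknown or untested is made for them only; others in the source may bear on it.

Measured in a functional assay on cells (Lymphocyte); a higher number here means a weaker inhibitor, a lower number a stronger inhibitor:

compound 1 `Nc1nc(N2CCN(C(=O)COc3ccc(Cl)cc3)CC2)c2cc(F)sc2n1` gives 700 nM
compound 2 `Nc1nc(N2CCN(C(=O)COc3ccc(Cl)cc3)CC2)c2ccsc2n1` gives 330 nM
compound 3 `Cc1cccc(NC(=O)N2CCN(c3nc(N)nc4sc(F)cc34)CC2)c1` gives 2800 nM

Compound 2 differs from compound 1 by hydrogen in place of fluoro on an aromatic carbon, and this change gave a 2.1-fold lower number from compound 1 to compound 2 (0.33 log units; beyond the scatter). Compound 3 differs from compound 1 by (3-methylphenyl)amino in place of (4-chlorophenoxy)methyl on a carbonyl carbon, and this change gave a 4.0-fold higher number from compound 1 to compound 3 (0.60 log units; beyond the scatter); compound 3 therefore stands with the highest number of the three in this assay, and the same difference separates the core of compound 4 from that of compound 2.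

Compound 4 `Cc1cccc(NC(=O)N2CCN(c3nc(N)nc4sccc34)CC2)c1` is not yet measured. It differs from compound 3 by hydrogen in place of fluoro on an aromatic carbon; the place is described in the same words as for the change from compound 1 to compound 2, so this is the same kind of change on a core that differs as told above.

Resting on the earlier step of a 2.1-fold lower number from compound 1 to compound 2 (0.33 log units; beyond the scatter), a step of about a 2.2-fold lower number from compound 3 to compound 4 (0.33 log units; beyond the scatter) is expected in this assay. Compound 4 is accordingly estimated at 1300 nM, expected to fall between 600 nM and 2800 nM.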

Compound 4, half-maximal inhibitory concentration: 930 nM
The estimate for compound 4 lay 1.4-fold (0.15 log units) above the measured number; measured number inside the range.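

In this assay, hydrogen in place of fluoro next to the ring sulfur gives a 3.0-fold lower number from compound 3 to compound 4 (0.48 log units; beyond the scatter), and the step carries from one core to the other: the same change on two cores in this assay, a 2.1-fold lower number (0.33 log units; beyond the scatter) from compound 1 to compound 2 and a 3.0-fold lower number (0.48 log units; beyond the scatter) from compound 3 to compound 4, 1.4-fold (0.15 log units) apart, within the scatter of two such steps.

The other change, (3-methylphenyl)amino in place of (4-chlorophenoxy)methyl on a carbonyl carbon, gives a 2.8-fold higher number from compound 2 to compound 4 (0.45 log units; beyond the scatter), and it also holds with or without the fluoro: the same change on two cores in this assay, a 4.0-fold higher number (0.60 log units; beyond the scatter) from compound 1 to compound 3 and a 2.8-fold higher number (0.45 log units; beyond the scatter) from compound 2 to compound 4, 1.4-fold (0.15 log units) apart, within the scatter of two such steps.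

Among these compounds, the two changes therefore combine without a visible interaction across these four compounds, but this rests on only two cores in this assay and does not show that the step would carry to other cores or explain why it occurs.

Still open, from the compounds shown here alone, is how chloro, methyl or nitrile would compare with hydrogen and fluoro at this place. Also open, going by these compounds, is whether the step holds with an alkylamino or a longer chain on the carbonyl carbon.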